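This account rests on a few compounds, and the source may have more. Where it says the series, first, only, none or still open, it means among the compounds named here.

Measured so far:
- compound 1 `COc1ccc(Nc2nccc(-c3cn(C)c4ccccc34)n2)c(OC)c1` gives 3410 nM
- compound 2 `COc1ccc(Nc2nccc(-c3sc(OC)nc3C)n2)c(OC)c1` gives 1400 nM

In a functional assay on MV4-11 cells (Homo sapiens) for inhibition, read by resazurin assay, with a stated time of 72 h (a lower number here means a stronger inhibitor of growth, a higher number a weaker inhibitor of growth), compound 2 (1400 nM) holds the lower of the two numbers, and its gap to compound 1 lies beyond the scatter. Among the measured compounds shown here, these two compounds differ in more than one place, so no single-change step is available as a guide.

Compound 3 `CCCSc1nc(C)c(-c2ccnc(Nc3ccc(OC)cc3OC)n2)s1` carries propylsulfanyl in place of methoxy on an aromatic carbon, next to the ring nitrogen and next to the ring sulfur (propylsulfanyl in place of methoxy on an aromatic carbon). For the measured compounds named here, no measured pair tests this change. With compound 2 (1400 nM) as the only close reference, a small shift toward a lower number is expected in this assay, probably none beyond the scatter. The expected step is a 1.4-fold lower number from compound 2 to compound 3 (0.15 log units; within the scatter) on this estimate. For compound 3 the estimated value is 1000 nM with 300 nM to 3500 nM as the expected range.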

Compound 3, concentration for 50% growth inhibition: 2240 nM
Beside the measured number, compound 3's estimate is 2.2-fold (0.35 log units) below it; measured number inside the range.
By their numbers in this assay, from the lowest: compounds 2, 3 and 1 (each within the scatter of the next, the first and the last beyond it).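

In this assay, among the compounds shown here, propylsulfanyl in place of methoxy on the aromatic carbon next to the ring nitrogen and next to the ring sulfur gives a 1.6-fold higher number from compound 2 to compound 3 (0.20 log units; within the scatter), the first single-change reading. At this position, the exchange of methoxy for propylsulfanyl, which has more heavy atoms and carries sulfur instead of oxygen, therefore produces no separation between the two compounds in this read-out. No measurement is available that bears on the reason for this result.

Going by these compounds, whether an amine, a carboxylic acid or a longer alkyl chain on this carbon would move the number beyond the scatter remains open. Also open, on these data alone, is whether the same exchange would read alike with another group in place of the methyl group on the ring.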